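The source may report more compounds than this note shows. Statements on the series, on what has been measured and on what is new or still open speak of the compounds shown alone.

The measured compounds are these. Compound 1, `CN1CCN(CCCCCn2c3c(c4ccccc42)C(=O)c2c[n+]([O-])c4ccccc4c2C3=O)CC1`, gives 870 nM in a functional assay on A549 cells (Homo sapiens) for cytotoxicity, read by MTT assay, with a stated time of 72 h; a higher number here means a weaker inhibitor, a lower number a stronger inhibitor. Compound 2, `O=C1c2c[n+]([O-])c3ccccc3c2C(=O)c2c1c1ccccc1n2Cc1cn([C@@H]2C[C@H](O)[C@@H](CO)O2)nn1`, gives 120 nM. Compound 3, `O=C1c2c[n+]([O-])c3ccccc3c2C(=O)c2c1c1ccccc1n2Cc1cn([C@H]2O[C@H](CO)[C@@H](O)[C@H]2O)nn1`, gives 2680 nM.

Among these three numbers compound 1 stands second highest: its number lies above that of compound 2 and below that of compound 3, and it is nearer to compound 3 than to compound 2. Both of those gaps are beyond the scatter.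

Compound 4, `O=C1c2c[n+]([O-])c3ccccc3c2C(=O)c2c1c1ccccc1n2CCCCN1CCNCC1`, is not yet measured. It differs from compound 1 in one place: piperazin-1-yl in place of (4-methylpiperazin-1-yl)methyl on a saturated chain carbon, four bonds along the chain from an aromatic nitrogen. Going by the values given here, the only measured step that differs in one place is a 22-fold higher number from compound 2 to compound 3 (1.35 log units; beyond the scatter), and that step concerns a hydroxy on a saturated ring carbon, a change of another kind at another part of the shared core, so it does not bear on the chain or the piperazine. Among the compounds with values here, no measured pair shows what shortening the chain or removing the methyl from the piperazine does here. The expectation is therefore a step of no more than the scatter from compound 1 to compound 4, in either direction, written as a 1.1-fold higher number from compound 1 to compound 4 (0.06 log units; within the scatter). Compound 4 is estimated at 1000 nM, with a range from 350 nM to 3000 nM.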

Compound 4, half-maximal inhibitory concentration: 540 nM
For compound 4 the middle estimate is 1.9-fold (0.27 log units) above the measured one; low and high end bracket the measured number.
By their numbers in this assay, from the lowest: compound 2; then compounds 4 and 1 (each within the scatter of the next); then compound 3.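

Replacing (4-methylpiperazin-1-yl)methyl with piperazin-1-yl on a saturated chain carbon, four bonds along the chain from an aromatic nitrogen, gives a 1.6-fold lower number from compound 1 to compound 4 (0.21 log units; within the scatter) in this assay. Going by these compounds alone, this is the first measured step at this position, and it shows that a change bringing in a hydrogen-bond donor and leaving fewer heavy atoms on the chain does not move the number past the scatter. The data on hand offer no explanation for this outcome.

Within the data shown here, the single step changes the chain and the piperazine methyl together, so the contribution of each remains open. Also open, on these data alone, is how other groups at this chain position would read in this assay, such as a morpholine, a dimethylamino group or a carboxylic acid.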